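A New Benzyl Group Tested on Compound 2

The source may report more compounds than this note shows. Statements on the series, on what has been measured and on what is new or still open speak of the compounds shown alone.

Three compounds share one core and differ only in the group on a saturated chain carbon bound to an oxygen on an aromatic ring. In a functional assay on Huh-7 cells (Homo sapiens) for antiproliferative activity, read by sulforhodamine B assay, with a stated time of 72 h (on this read-out lower numbers stand for stronger inhibition and higher numbers for weaker inhibition), compound 1 `Cc1cc(C)cc(COc2ccc(-c3cc(CN4CCN(Cc5ccc(C(F)(F)F)cc5)CC4)no3)cc2)c1` gives 600 nM, compound 3 `COc1cc(COc2ccc(-c3cc(CN4CCN(Cc5ccc(C(F)(F)F)cc5)CC4)no3)cc2)cc(OC)c1OC` gives 500 nM, and compound 2 `N#Cc1cccc(COc2ccc(-c3cc(CN4CCN(Cc5ccc(C(F)(F)F)cc5)CC4)no3)cc2)c1` gives 100 nM, the lowest of the three. The steps of a 6.0-fold lower number from compound 1 to compound 2 (0.78 log units; beyond the scatter) and a 5.0-fold higher number from compound 2 to compound 3 (0.70 log units; beyond the scatter) lie beyond the scatter, while a 1.2-fold lower number from compound 1 to compound 3 (0.08 log units; within the scatter) does not. Compound 4 `N#Cc1cccc(COc2ccc(-c3cc(CN4CCN(Cc5cccc(F)c5)CC4)no3)cc2)c1` alters a different place: 3-fluorophenyl in place of 4-(trifluoromethyl)phenyl on a saturated chain carbon bound to an amine nitrogen in a ring. Within the data shown here, none of the measured steps touches that position, so they offer no direct guide, and no step beyond the scatter is expected in either direction. Compound 4 is therefore estimated at 150 nM, within 50 nM to 450 nM, an expected step of a 1.5-fold higher number from compound 2 to compound 4 (0.18 log units; within the scatter).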

Compound 4, half-maximal inhibitory concentration: 2700 nM
Compound 4: the middle estimate sits 18-fold (1.26 log units) below what was measured, and the stated range ends below it.
By their numbers in this assay, from the lowest: compound 2; then compounds 3 and 1 (each within the scatter of the next); then compound 4.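

In this assay, this position on a saturated chain carbon bound to an amine nitrogen in a ring proves highly sensitive: replacing 4-(trifluoromethyl)benzyl with 3-fluorobenzyl gives a 27-fold higher number from compound 2 to compound 4 (1.43 log units; beyond the scatter) and is a larger step than any among compound 1, compound 2 and compound 3. Activity therefore depends on this group as well as on the one varied earlier. Nothing measured here explains the loss.

The substituent and its place on the ring change together, so their contributions remain unseparated. A 4-fluorobenzyl or 3-(trifluoromethyl)benzyl group at this position could tell them apart.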